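Swapping the amine substituent on a piperidine-linked indole core

A few compounds are considered here, and "the series" means these few. Any claim that something is new, unique, unknown or untested is made for them only; others in the source may bear on it.

Measured compounds:
- compound 1 `COC[C@H](NC1CCN(CCCc2c[nH]c3ccc(-n4cnnc4)cc23)CC1)c1ccccc1`: 0.9 nM
- compound 2 `OC[C@H](NC1CCN(CCCc2c[nH]c3ccc(Cn4cncn4)cc23)CC1)c1ccccc1`: 32 nM

Both were tested in an assay on CHO cells for agonist activity at 5-hydroxytryptamine receptor 1D (Homo sapiens), read by GTPgammaS binding; a lower number here means that less compound is needed, a higher number that more compound is needed for the effect. Compound 1 gives the lowest of the two numbers; compound 2 sits a long way higher, well beyond the usual scatter, but the two differ in more than one place, so the values only show that gap and not its cause.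

Compound 3 `c1ccc2c(c1)CCC2NCC1CCN(CCCc2c[nH]c3ccc(-n4cnnc4)cc23)CC1` has not yet been measured. It is derived from compound 1 by one change: ((2,3-dihydro-1H-inden-1-yl)amino)methyl in place of (2-methoxy-1-phenylethyl)amino on a saturated ring carbon. The group that leaves carries one hydrogen-bond acceptor more than the one that enters, and the stereocentre is lost, while the size of the group stays the same. Among the measured compounds shown here, no measured pair shows this change, so the expectation is loose. A modest loss is expected, a step of a 3.3-fold higher number from compound 1 to compound 3 (0.52 log units; beyond the scatter), with compound 3 estimated at 3 nM in a range from 0.8 nM to 15 nM.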

Compound 3, half-maximal effective concentration: 1.3 nM
Estimate against measurement, compound 3: 2.3-fold (0.36 log units) above; measured number inside the range.
By their numbers in this assay, from the lowest: compounds 1 and 3 (each within the scatter of the next); then compound 2.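

In this assay, among the compounds shown here, the change gives a 1.4-fold higher number from compound 1 to compound 3 (0.16 log units; within the scatter), the first comparison here that differs in only one place. It shows that, on this saturated ring carbon, ((2,3-dihydro-1H-inden-1-yl)amino)methyl can stand in place of (2-methoxy-1-phenylethyl)amino with no difference that can be told from the scatter, even though the oxygen and the defined stereocentre of the leaving group are gone. No measurement shown explains why these two groups give such similar numbers.

As far as these compounds go, this single swap alters the oxygen, the stereocentre and the ring together, so what each alteration contributes alone stays open. Also open, from the compounds shown here alone, is how the number would respond to a plain primary amine, a carboxylic acid or a longer alkyl chain on the same ring carbon.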